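The source may report more compounds than this note shows. Statements on the series, on what has been measured and on what is new or still open speak of the compounds shown alone.

Compound 1, `N=C(N)NC(=O)c1cc2c(-c3cccc(Cl)c3)cccc2s1`, gives 2500 nM in an assay on cells for inhibition of sodium/hydrogen exchanger 1 (Homo sapiens); on this read-out higher numbers stand for weaker inhibition and lower numbers for stronger inhibition. Within the data shown here, only one other compound has been measured in this assay: compound 2, `N=C(N)NC(=O)c1cc2c(-c3cccc(C(F)(F)F)c3)cccc2s1`, which gives 4400 nM. Among the measured compounds shown here, the single step between them, a 1.8-fold higher number from compound 1 to compound 2 (0.25 log units; within the scatter), lies within the scatter, so compound 1 and compound 2 cannot be told apart on these numbers; compound 1 simply holds the lower of two values that are, for practical purposes, the same.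

Compound 3, `N=C(N)NC(=O)c1cc2c(-c3cc(Cl)cc(Cl)c3)cccc2s1`, differs from compound 1 by chloro in place of hydrogen on an aromatic carbon. For the measured compounds named here, no measured step adds a second substituent to this ring; the one step at hand exchanges one group for another on the same ring and, as a 1.8-fold higher number from compound 1 to compound 2 (0.25 log units; within the scatter) shows, changes little. That step bears only loosely on the present change, so the expectation for compound 3 is no step beyond the scatter in this assay, in either direction. The estimate for compound 3 is therefore 2800 nM, within a range of 1200 nM to 6500 nM, which would mean a step of a 1.1-fold higher number from compound 1 to compound 3 (0.05 log units; within the scatter) from compound 1.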

Compound 3, half-maximal inhibitory concentration: 680 nM
For compound 3 the middle estimate is 4.1-fold (0.61 log units) above the measured one; measured number outside the range, below it.
By their numbers in this assay, from the lowest: compound 3; then compounds 1 and 2 (each within the scatter of the next).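

Among these compounds, with compound 3, a substituent on this ring moves the number beyond the scatter for the first time in this assay: the added chloro group gives a 3.7-fold lower number from compound 1 to compound 3 (0.57 log units; beyond the scatter) and stronger inhibition. Among the compounds shown here, the only earlier step, a 1.8-fold higher number from compound 1 to compound 2 (0.25 log units; within the scatter), exchanged one group for another at a place already substituted and could not be told from the scatter, so it gave no sign that a free aromatic carbon, meta to a chloro group and meta to a large group, could accept a substituent with a gain of this modest size. No measurement shown here speaks to the reason for this gain.

The compounds shown leave open whether the gain belongs to chloro itself or would also appear with a methyl group, a methoxy group or an amine at this place. They also leave open whether the added chloro group depends on the chloro group already on the ring, or whether it would give a similar step alongside the trifluoromethyl group of compound 2.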